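The source may hold more compounds than are shown below. What is called first, only, known or untested is meant among the compounds shown, and "the series" means these compounds.

Measured in an ADME assay on the whole organism (Rattus norvegicus) for metabolic stability, using cassette dosing; a higher number here means that the compound lasts longer, a lower number that the compound disappears faster:
Compound 1 `CCc1cc(NC(=O)Nc2cccc(C(F)(F)F)c2)cc(Cl)c1Oc1cc(NC)ncn1`: 3.7 h
Compound 2 `CNc1cc(Oc2ccc(NC(=O)Nc3cccc(C(F)(F)F)c3)cc2)ncn1`: 3.2 h
Compound 3 `CNc1cc(Oc2c(C)cc(NC(=O)Nc3cccc(C(F)(F)F)c3)cc2C)ncn1`: 2.4 h

Compound 2, at 3.2 h, lies within the scatter of both compound 1 and compound 3, so the three values cannot be ranked. Compound 4 `O=C(Nc1ccc(Oc2cc(NCCO)ncn2)cc1)Nc1cccc(C(F)(F)F)c1` differs from compound 2 by one change, hydroxymethyl in place of hydrogen on a saturated chain carbon bound to a nitrogen on an aromatic ring, which makes methylamino into (2-hydroxyethyl)amino. Among the measured compounds shown here, no measured pair shows the size of such a step. The expected step in this assay is a small fall, a 1.5-fold lower number from compound 2 to compound 4 (0.16 log units; within the scatter), not clearly beyond the scatter. The half-life of compound 4 is estimated at 2.2 h, with an expected range of 1 h to 4.2 h.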

Compound 4, half-life: 4.5 h
Beside the measured number, compound 4's estimate is 2.0-fold (0.31 log units) below it; measured number outside the range, above it.
By their numbers in this assay, from the lowest: compounds 3, 2, 1 and 4 (each within the scatter of the next).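

In this assay, among the compounds shown here, the change from methylamino to (2-hydroxyethyl)amino gives a 1.4-fold higher number from compound 2 to compound 4 (0.15 log units; within the scatter), the first step that isolates a single place. The chain at this position therefore carries a hydroxymethyl with no difference in half-life that can be told from the scatter. Nothing available explains this result.

Open, on these data alone, is how a longer chain, a methoxy group or an amine at the end of this chain would read here. Also open, as far as these compounds go, is whether the same change reads alike on the cores of compound 1 and compound 3.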